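This account rests on a few compounds, and the source may have more. Where it says the series, first, only, none or still open, it means among the compounds named here.

Measured compounds:
compound 1 `O=C(Nn1c(-c2cccc([N+](=O)[O-])c2)nc2c(-c3ccc(F)cc3)n[nH]c2c1=O)c1ccccc1` gives 92% in a functional assay on HT-29 cells (Homo sapiens) for cytotoxicity, read by sulforhodamine B assay, with a stated time of 2 days, tested at 100 uM; a lower number here means less inhibition, a higher number more inhibition at the concentration tested (going by the name of the read-out)
compound 2 `O=C(Nn1c(-c2cccc([N+](=O)[O-])c2)nc2c(-c3ccco3)n[nH]c2c1=O)c1ccccc1` gives 21.2%

Compound 2 stands lowest of the two numbers; its nearest neighbour is compound 1, and the step of a number 70.8 percentage points lower from compound 1 to compound 2 (beyond the scatter) lies beyond the scatter. Compound 3 `O=C(Nn1c(-c2cccc([N+](=O)[O-])c2)nc2c(CCc3ccccc3)n[nH]c2c1=O)c1ccccc1` has not yet been measured. It differs from compound 2 by phenethyl in place of furan-2-yl on an aromatic carbon. Among the compounds with values here, the only measured step that bears on this position is the one from compound 1 to compound 2, where furan-2-yl replaced 4-fluorophenyl and the number fell sharply. Compound 3 brings back a six-membered ring of carbon only at that position, though now with a two-carbon link, so the step is expected to go upward, but the size is uncertain. Compound 3 is therefore estimated at 50% (range 15% to 90%), an expected step of a number 28.8 percentage points higher from compound 2 to compound 3 (beyond the scatter).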

Compound 3, a percentage reported as inhibition, at one concentration (the size of the read-out at that concentration, not a potency): 89.7%
The estimate for compound 3 lay 39.7 percentage points below the measured number; measured number inside the range.
By their numbers in this assay, from the lowest: compound 2; then compounds 3 and 1 (each within the scatter of the next).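

In this assay, phenethyl in place of furan-2-yl gave a number 68.5 percentage points higher from compound 2 to compound 3 (beyond the scatter), so the low number of compound 2 does not extend to every larger group at this aromatic carbon. The second step, a number 2.3 percentage points lower from compound 1 to compound 3 (within the scatter), places phenethyl level with 4-fluorophenyl, which shows that a six-membered aromatic ring of carbon only need not sit directly on the core for the high number to be kept. Among these three compounds, only the one carrying furan-2-yl stands apart, and nothing available here explains that gap.

Going by these compounds, it remains open whether the low number belongs to furan-2-yl alone or to other five-membered aromatic rings as well. Also open, on these data alone, is what an amine, a carboxylic acid or a longer chain ending in a phenyl ring would give at this carbon.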